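This account rests on a few compounds, and the source may have more. Where it says the series, first, only, none or still open, it means among the compounds named here.

Of the compounds shown here, two have numbers so far in an ADME assay on THP-1 cells (Homo sapiens) for cytotoxicity, read by flow cytometry and propidium iodide staining, with a stated time of 72 h; on this read-out lower numbers stand for stronger inhibition and higher numbers for weaker inhibition. Compound 1 (`CC(=O)Nc1ccc2oc(-c3cccc(F)c3)c(O)c(=O)c2c1`) gives 36000 nM, while compound 2 (`COc1cccc(-c2oc3ccc(NC(C)=O)cc3c(=O)c2OC)c1`) gives 5000 nM. Compound 2 therefore stands as the lower of the two, and its gap to compound 1 lies beyond the usual scatter of repeated measurements.

The next structure, compound 3 (`COc1c(-c2cccc(F)c2)oc2ccc(NC(C)=O)cc2c1=O`), departs from compound 2 in one place, where 3-methoxyphenyl becomes 3-fluorophenyl: fluoro in place of methoxy on an aromatic carbon. This places fluoro in place of methoxy on an aromatic carbon. Among the measured compounds shown here, no measured pair shows this change on its own, so the data offer no direct measure of its size in this assay. For the measured compounds named here, the only other reference is compound 1 at 36000 nM, which sits on the higher side of compound 2. A modest move toward a higher number, meaning weaker inhibition, is therefore expected, though a step within the scatter would be no surprise. The expected change is a 1.8-fold higher number from compound 2 to compound 3 (0.26 log units; within the scatter). For compound 3 the estimated value is 9000 nM, with an expected range from 3000 nM to 30000 nM.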

Compound 3, half-maximal inhibitory concentration: > 125000 nM
Compound 3: no number, only a limit; the forecaster's own chance of this, stated with the estimate: 10%; middle value at least 13-fold (1.14 log units) from the limit.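

The reading for compound 3 in this assay is a limit and not a number, so the steps that end on it have a lower bound but no upper end: the limit of > 125000 nM in this assay, at which 1 of the 3 values shown sits.

Even so, this place on the six-membered aromatic ring proves far from indifferent, as fluoro in place of methoxy on this aromatic carbon gives an at least 25-fold higher number from compound 2 to compound 3 (1.39 log units; beyond the scatter), the first size measured for this change. The oxygen on the shared core also counts with 3-fluorophenyl held fixed, as methyl in place of hydrogen there gives an at least 3.4-fold higher number from compound 1 to compound 3 (0.54 log units; beyond the scatter), so both single changes leading to compound 3 move the number upward, beyond the scatter.

The compounds shown leave open whether the step from the methoxy compound reflects the methoxy leaving or the fluoro entering, a question that a chloro group, an amine or a longer ethoxy chain at the same place would help to separate. They also leave open whether methyl in place of hydrogen on that oxygen moves the number the same way when the 3-methoxyphenyl group is present.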